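Pyrrolidin-2-yl to piperidin-2-yl on compound 1

The compounds below may be only part of what the source reports. "The series", "measured", "known", "first", "only" and "open" are said of these compounds alone.

Among the measured compounds shown here, in a functional assay on HepG2 cells (Homo sapiens) for inhibition, read by MTT assay, with a stated time of 24 h (a lower number here means a stronger inhibitor, a higher number a weaker inhibitor), compound 1 (`FC(F)(F)c1cc(NC[C@H]2CCCN2)c2cn[nH]c2c1`) gives 16300 nM, the higher of the two numbers so far, while compound 2 (`O=[N+]([O-])c1ccc(Cl)cc1CNc1cc(C(F)(F)F)cc2[nH]ncc12`) gives 1300 nM, a gap beyond the scatter. Compound 3 (`FC(F)(F)c1cc(NC[C@@H]2CCCCN2)c2cn[nH]c2c1`) is not yet measured. Its difference from compound 1 is piperidin-2-yl in place of pyrrolidin-2-yl on a saturated chain carbon bound to a nitrogen on an aromatic ring, with piperidin-2-yl in place of pyrrolidin-2-yl on a saturated chain carbon bound to a nitrogen on an aromatic ring. For the measured compounds named here, no measured pair shows this change, so only a small move toward stronger inhibition is expected, and the expected step of a 1.3-fold lower number from compound 1 to compound 3 (0.10 log units; within the scatter) stays within the scatter. For compound 3 the estimated value is 13000 nM, with a range of 6000 nM to 30000 nM.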

Compound 3, half-maximal inhibitory concentration: 19900 nM
For compound 3 the middle estimate is 1.5-fold (0.18 log units) below the measured one, within the range that was stated.
By their numbers in this assay, from the lowest: compound 2; then compounds 1 and 3 (each within the scatter of the next).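

In this assay, piperidin-2-yl in place of pyrrolidin-2-yl on a saturated chain carbon bound to a nitrogen on an aromatic ring gives a 1.2-fold higher number from compound 1 to compound 3 (0.09 log units; within the scatter) and so shows that the five-membered and six-membered rings read alike at this place. Among the compounds shown here, this is the first single-place step, and it rests on this one pair. Nothing measured here accounts for the result.

Still open, going by these compounds, is whether morpholin-2-yl, with its ring oxygen, or an open-chain amine such as 2-aminoethyl at this place would read the same on the core of compound 1.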